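From Fluoro to Chloro in a Three-Compound Series

The compounds below may be only part of what the source reports. "The series", "measured", "known", "first", "only" and "open" are said of these compounds alone.

Compound 1 `Nc1ccc(-c2cc(=O)c3c(N)c(Cl)cc(Cl)c3o2)cc1` gives 610 nM
Compound 2 `Nc1ccc(-c2cc(=O)c3c(N)ccc(F)c3o2)cc1` gives 170 nM
Compound 3 `Nc1ccc(-c2cc(=O)c3c(N)c(F)cc(F)c3o2)cc1` gives 46 nM

All three were measured in a functional assay on MCF7 cells (Homo sapiens) for inhibition, in the presence of a further agent that is not named here; on this read-out higher numbers stand for weaker inhibition and lower numbers for stronger inhibition. Compound 2 holds the middle place among these numbers, with compound 1 higher and compound 3 lower, both gaps beyond the usual scatter.

Compound 4 `Nc1ccc(-c2cc(=O)c3c(N)ccc(Cl)c3o2)cc1` keeps the core of compound 2 and changes one group: chloro in place of fluoro on an aromatic carbon. This places chloro in place of fluoro, para to an amino group.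

Among the measured compounds shown here, no measured step makes this exact swap, so the evidence is indirect. For the measured compounds named here, the one measured step, a 3.7-fold lower number from compound 2 to compound 3 (0.57 log units; beyond the scatter), shows that adding fluoro can lower the number. Compound 1 carries chloro in place of each fluoro of compound 3, and compound 1 gives 610 nM while compound 3 gives 46 nM. That gap spans more than one swap, so only part of it is expected here, pointing toward weaker inhibition. The expected change is a 2.4-fold higher number from compound 2 to compound 4 (0.37 log units; beyond the scatter). For compound 4 the estimated value is 400 nM, with an expected range from 150 nM to 1000 nM.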

Compound 4, half-maximal inhibitory concentration: 250 nM
The estimate for compound 4 lay 1.6-fold (0.20 log units) above the measured number; the measured number falls inside the stated range.
By their numbers in this assay, from the lowest: compound 3; then compounds 2 and 4 (each within the scatter of the next); then compound 1.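

In this assay, the swap at this carbon, para to an amino group, gives a 1.5-fold higher number from compound 2 to compound 4 (0.17 log units; within the scatter), so fluoro and chloro cannot be told apart here when no second halogen is present. Among the compounds shown here, the step of a 2.4-fold lower number from compound 1 to compound 4 (0.39 log units; beyond the scatter) isolates the second chloro for the first time: taking it away brings stronger inhibition. Adding a second halogen therefore does not act the same way in both pairs, since fluoro lowered the number in a 3.7-fold lower number from compound 2 to compound 3 (0.57 log units; beyond the scatter), while the extra chloro of compound 1 goes with a higher number than compound 4.

No measurement shown explains why the two halogens differ when a second one is present. The compounds also leave open how a larger or different group, such as methoxy or a nitrile, would fare at the carbon para to the amino group.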